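A few compounds are considered here, and "the series" means these few. Any claim that something is new, unique, unknown or untested is made for them only; others in the source may bear on it.

Three compounds share one core and differ only in the group attached to it. In a functional assay on NCI-H226 cells (Homo sapiens) for inhibition, read by sulforhodamine B assay, with a stated time of 48 h, tested at 10 uM (a higher number here means more inhibition at the concentration tested (going by the name of the read-out), a lower number less inhibition), compound 1 `O=Cc1ccc(-c2cn3ccnc3c(-c3ccc4ncn(C5CCCCC5)c4c3)n2)cc1` gives 0.53%, compound 2 `c1ccc2c(-c3cn4ccnc4c(-c4ccc5ncn(C6CCCCC6)c5c4)n3)cccc2c1` gives 9.45%, and compound 3 `Fc1ccc(-c2cn3ccnc3c(-c3ccc4ncn(C5CCCCC5)c4c3)n2)cc1` gives 23.3%, the highest of the three: it stands a number 13.9 percentage points higher from compound 2 to compound 3 (beyond the scatter) and a number 22.8 percentage points higher from compound 1 to compound 3 (beyond the scatter), while a number 8.9 percentage points higher from compound 1 to compound 2 (within the scatter) separates the other two. Compound 4 `c1cn2cc(-c3ccsc3)nc(-c3ccc4ncn(C5CCCCC5)c4c3)c2n1` carries thiophen-3-yl in place of 4-fluorophenyl on an aromatic carbon. For the measured compounds named here, only the step from compound 2 to compound 3 exchanged one whole ring for another at this position, and it was modest; no measured compound has a five-membered ring there, so the direction is uncertain. A modest drop in this assay is expected, a number 11.3 percentage points lower from compound 3 to compound 4 (beyond the scatter). Compound 4 is therefore estimated at 12%, within 0% to 30%.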

Compound 4, a percentage reported as inhibition, at one concentration (the size of the read-out at that concentration, not a potency): 6.34%
For compound 4 the middle estimate is 5.7 percentage points above the measured one; the range from low to high includes it.
By their numbers in this assay, from the lowest: compounds 1, 4 and 2 (each within the scatter of the next); then compound 3.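

In this assay, the first five-membered ring at this position, thiophen-3-yl in place of 4-fluorophenyl, gives a number 17 percentage points lower from compound 3 to compound 4 (beyond the scatter), which leaves compound 3 alone at the top of the four. The other two steps, a number 3.1 percentage points lower from compound 2 to compound 4 (within the scatter) and a number 5.8 percentage points higher from compound 1 to compound 4 (within the scatter), show no separation from the naphthalen-1-yl and 4-formylphenyl groups. No evidence here explains the drop from 4-fluorophenyl. On these data alone, whether a pyridin-3-yl ring or a phenyl ring carrying an amine would match or pass compound 3 stays open.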